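Saturated replacement of the triazole on the amide carbonyl

The source may report more compounds than this note shows. Statements on the series, on what has been measured and on what is new or still open speak of the compounds shown alone.

Compound 1 `CC1(C)Cc2c(sc(NC(=O)c3nnc[nH]3)c2C(N)=O)C(C)(C)O1` is the reference point of the series. In an assay on cells for positive allosteric modulation of Cystic fibrosis transmembrane conductance regulator variant F508del (Homo sapiens), with stated times of 10 min and 7 s, in the presence of a further agent that is not named here (a lower number here means that less compound is needed, a higher number that more compound is needed for the effect), compound 1 gives 467 nM, the higher of the two numbers recorded as actual values in this set. Compound 2 `CC1(C)Cc2c(sc(NC(=O)Cc3ccn[nH]3)c2C(N)=O)C(C)(C)O1` gives 136 nM, which is a 3.4-fold lower number from compound 1 to compound 2 (0.54 log units; beyond the scatter). Compound 3 `CC1(C)Cc2c(sc(NC(=O)C3CNC(=O)C3)c2C(N)=O)C(C)(C)O1` reaches only a limit here, > 10000 nM. That limit is the limit of > 10000 nM in this assay, at which 1 of the 3 values shown sits. The steps to compound 3 are an at least 21-fold higher number from compound 1 to compound 3 (1.33 log units; beyond the scatter) and an at least 73-fold higher number from compound 2 to compound 3 (1.86 log units; beyond the scatter).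

Compound 4 `CC1(C)Cc2c(sc(NC(=O)[C@H](O)C(C)(C)C)c2C(N)=O)C(C)(C)O1` has not yet been measured. It differs from compound 1 by 1-hydroxy-2,2-dimethylpropyl in place of 4H-1,2,4-triazol-3-yl on a carbonyl carbon. Both measured steps that leave the triazole bear on it: the one keeping a five-membered aromatic ring was modest and favourable, the one moving to a ring that is not aromatic was large and unfavourable. Compound 4 moves to a group with no ring at all and is therefore expected to sit closer to compound 3, with a step of a 6.4-fold higher number from compound 1 to compound 4 (0.81 log units; beyond the scatter) in this assay. The estimate for compound 4 is 3000 nM, within 500 nM to 10000 nM, and a real chance remains that only a limit is obtained.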

Compound 4, half-maximal effective concentration: 127 nM
For compound 4 the middle estimate is 24-fold (1.37 log units) above the measured one, and the stated range ends above it.
By their numbers in this assay, from the lowest: compounds 4 and 2 (each within the scatter of the next); then compound 1. At a limit, above all of these: compound 3.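

A ring on this carbonyl carbon is not needed for activity in this assay: with the open-chain 1-hydroxy-2,2-dimethylpropyl group there is a 3.7-fold lower number from compound 1 to compound 4 (0.57 log units; beyond the scatter). This group and the (1H-pyrazol-5-yl)methyl group cannot be told apart, with a 1.1-fold lower number from compound 2 to compound 4 (0.03 log units; within the scatter), so an aromatic ring gives no visible advantage over this open chain. The earlier contrast between aromatic and non-aromatic groups therefore does not hold as a rule, since compound 4 goes against it, and the gap to the 5-oxopyrrolidin-3-yl group stands at an at least 78-fold lower number from compound 3 to compound 4 (1.89 log units; beyond the scatter), where the value of compound 3 is a limit: the limit of > 10000 nM in this assay, at which 1 of the 4 values shown sits.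

From the compounds shown here alone, whether the hydroxy group or the dimethylpropyl part carries the result of compound 4 remains open, as does the effect of the opposite configuration at its stereocentre. Going by these compounds, how an amine or a carboxylic acid in place of that hydroxy group would read is also open.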